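A Small Alkoxy Trim on a Sulfonylurea Vasorelaxant

This account rests on a few compounds, and the source may have more. Where it says the series, first, only, none or still open, it means among the compounds named here.

Compound 1 `COc1ccc(Cl)cc1C(C)NC(=O)N(C)S(=O)(=O)c1ccc(Cl)cc1` and compound 2 `CCOc1ccc(Cl)cc1C(C)NC(=O)N(C)S(=O)(=O)c1ccc(Cl)cc1` share one core, while compound 3 `CCOc1ccc(Br)cc1C(C)NC(=O)NS(=O)(=O)c1ccc(Cl)cc1` rests on a different core; the difference between the two cores is not broken down here. In a functional assay on thoracic aorta (Rattus norvegicus, strain Wistar), with a stated time of 15 min (a higher number here means that more compound is needed for the effect, a lower number that less compound is needed), compound 1 gives 20000 nM, and compound 2 gives 14600 nM. Between them lies (hydrogen in place of methyl on a saturated chain carbon bound to an oxygen on an aromatic ring), which made a 1.4-fold higher number from compound 2 to compound 1 (0.14 log units; within the scatter). Compound 3 gives 171000 nM in this assay. Compound 4 `COc1ccc(Br)cc1C(C)NC(=O)NS(=O)(=O)c1ccc(Cl)cc1` has not been measured; it differs from compound 3 by hydrogen in place of methyl on a saturated chain carbon bound to an oxygen on an aromatic ring, the same change in the same place, so this change appears in two pairs here. Because the measured example moved by a 1.4-fold higher number from compound 2 to compound 1 (0.14 log units; within the scatter), the step for compound 4 is expected to be about a 1.2-fold higher number from compound 3 to compound 4 (0.07 log units; within the scatter). Compound 4 is therefore estimated at 200000 nM, most likely between 80000 nM and 500000 nM.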

Compound 4, half-maximal effective concentration: 80900 nM
Compound 4: the middle estimate sits 2.5-fold (0.39 log units) above what was measured; low and high end bracket the measured number.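

Trimming ethoxy to methoxy on the core of compound 3 gives a 2.1-fold lower number from compound 3 to compound 4 (0.33 log units; beyond the scatter) in this assay. Set beside the earlier step, this shows that the same small change did not carry over unchanged from one core to the other: the same change on two cores in this assay, a 1.4-fold higher number (0.14 log units; within the scatter) from compound 2 to compound 1 and a 2.1-fold lower number (0.33 log units; beyond the scatter) from compound 3 to compound 4, 2.9-fold (0.46 log units) apart, beyond the scatter of two such steps

For the compounds shown here, with only two pairs, this does not show which difference between the two cores separates the results, nor what the change would do on a third core.

The compounds shown reach only from methoxy to ethoxy at this place. Going by these compounds, what a longer chain such as propoxy, or a hydroxyl group in place of the alkoxy group, would do on either core stays open.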